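The source may hold more compounds than are shown below. What is called first, only, known or untested is meant among the compounds shown, and "the series" means these compounds.

Measured so far in a functional assay on FM3A cells (Mus musculus) for inhibition, read by cell counting, with a stated time of 2 days; a lower number here means a stronger inhibitor, a higher number a weaker inhibitor:
compound 1 `C=C(Br)C(=O)Nc1cccc(-c2cn3nc(-c4ccc(F)cc4)sc3n2)c1` gives 610 nM
compound 2 `C=C(Br)C(=O)Nc1cccc(-c2cn3nc(-c4ccc(Cl)cc4)sc3n2)c1` gives 2000 nM
compound 3 `Nc1cccc(-c2cn3nc(-c4ccc(Cl)cc4)sc3n2)c1` gives 160000 nM

Compound 1 differs from compound 2 by fluoro in place of chloro on an aromatic carbon; the step in this assay is a 3.3-fold lower number from compound 2 to compound 1 (0.52 log units; beyond the scatter). Compound 3 differs from compound 2 by hydrogen in place of (1-bromoethenyl)carbonyl on a nitrogen on an aromatic ring, and this change makes by far the larger step, an 80-fold higher number from compound 2 to compound 3 (1.90 log units; beyond the scatter), leaving compound 3 with the highest number of the three in this assay.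

Compound 4 `Nc1cccc(-c2cn3nc(-c4ccc(F)cc4)sc3n2)c1` is not yet measured. It differs from compound 3 by fluoro in place of chloro on an aromatic carbon; this is the same change as that from compound 2 to compound 1, the place lines read alike, only now on the core of compound 3 rather than the core of compound 2. The expected step in this assay is a 2.7-fold lower number from compound 3 to compound 4 (0.43 log units; beyond the scatter), resting on the single earlier occurrence a 3.3-fold lower number from compound 2 to compound 1 (0.52 log units; beyond the scatter); with one precedent only, and that on a core carrying the (1-bromoethenyl)carbonyl group, the range is kept wide. Compound 4 is estimated at 60000 nM, expected between 20000 nM and 200000 nM.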

Compound 4, half-maximal inhibitory concentration: 33000 nM
Estimate against measurement, compound 4: 1.8-fold (0.26 log units) above, within the range that was stated.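

In this assay, fluoro in place of chloro carries from one core to the other, with a 4.8-fold lower number from compound 3 to compound 4 (0.69 log units; beyond the scatter) matching the step on the core bearing the (1-bromoethenyl)carbonyl group: the same change on two cores in this assay, a 3.3-fold lower number (0.52 log units; beyond the scatter) from compound 2 to compound 1 and a 4.8-fold lower number (0.69 log units; beyond the scatter) from compound 3 to compound 4, 1.5-fold (0.17 log units) apart, within the scatter of two such steps

Hydrogen in place of (1-bromoethenyl)carbonyl also carries across, with a 54-fold higher number from compound 1 to compound 4 (1.73 log units; beyond the scatter) on the fluoro side matching the step on the chloro side: the same change on two cores in this assay, an 80-fold higher number (1.90 log units; beyond the scatter) from compound 2 to compound 3 and a 54-fold higher number (1.73 log units; beyond the scatter) from compound 1 to compound 4, 1.5-fold (0.17 log units) apart, within the scatter of two such steps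

The two changes therefore behave as independent across these four compounds, but this rests on a single pair of steps for each change, within one assay and one series, and it neither extends to other cores nor explains why either step has its size.

The compounds shown leave open how a bromo or methoxy group, or a hydrogen, would compare with fluoro and chloro at the same place. They also leave open whether the bromine of the (1-bromoethenyl)carbonyl group matters, which a plain acetyl or ethenylcarbonyl group on the nitrogen would test.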